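Para-trifluoromethyl analogue of a diaryl imidazoline series

The source may hold more compounds than are shown below. What is called first, only, known or untested is meant among the compounds shown, and "the series" means these compounds.

Measured so far:
Compound 1 `Fc1ccc(C2(c3ccc(F)cc3)CNC(c3ccccc3)=N2)cc1`: 32 nM
Compound 2 `Fc1ccc(C2(c3ccc(F)cc3)CNC(c3cccc(Cl)c3)=N2)cc1`: 5.4 nM
Compound 3 `Fc1ccc(C2(c3ccc(F)cc3)CNC(c3cccc(C(F)(F)F)c3)=N2)cc1`: 6.2 nM

In an assay on LM cells for displacement of a labelled ligand from Neuropeptide Y receptor type 5 (Homo sapiens) (on this read-out lower numbers stand for stronger inhibition and higher numbers for weaker inhibition), compound 1 gives the highest number of the three; compounds 2 and 3 both sit well below it. Compound 4 `Fc1ccc(C2(c3ccc(F)cc3)CNC(c3ccc(C(F)(F)F)cc3)=N2)cc1` differs from compound 1 by trifluoromethyl in place of hydrogen on an aromatic carbon. Among the compounds with values here, two measured steps bear on this change, both adding a group to an aromatic carbon of the same six-membered aromatic ring of carbon only: a 5.9-fold lower number from compound 1 to compound 2 (0.77 log units; beyond the scatter) and a 5.2-fold lower number from compound 1 to compound 3 (0.71 log units; beyond the scatter), both beyond the scatter and of modest size. Compound 4 places the group at a different carbon of that ring, for which no direct comparison exists. A smaller gain than those two steps is expected, so compound 4 is estimated at 12 nM (range 4 nM to 40 nM), a step of a 2.7-fold lower number from compound 1 to compound 4 (0.43 log units; beyond the scatter).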

Compound 4, half-maximal inhibitory concentration: 160 nM
Compound 4: the middle estimate sits 13-fold (1.12 log units) below what was measured; measured number above the stated range.
By their numbers in this assay, from the lowest: compounds 2 and 3 (each within the scatter of the next); then compound 1; then compound 4.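

In this assay, trifluoromethyl on the aromatic carbon para to a large group moves the number the opposite way: a 5.0-fold higher number from compound 1 to compound 4 (0.70 log units; beyond the scatter), whereas the same group on another carbon of that ring gave a 5.2-fold lower number from compound 1 to compound 3 (0.71 log units; beyond the scatter). The result of adding trifluoromethyl to this ring therefore depends on which carbon carries it. Nothing available accounts for this reversal.

As far as these compounds go, whether the higher number belongs to this position generally or to trifluoromethyl in particular stays open. The compounds shown do not say how chloro, methoxy or an amine would fare on this same carbon.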